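This account rests on a few compounds, and the source may have more. Where it says the series, first, only, none or still open, it means among the compounds named here.

Within the data shown here, compound 1 `C=CC(=O)Nc1cc(Nc2ncc(Cl)c(Nc3ccccc3S(=O)(=O)C(C)C)n2)c(OC)cc1N1CCN(C)CC1` stands at the stronger end of the two numbers measured so far: in a functional assay on NCI-H1975 cells (Homo sapiens) for inhibition, read by CellTiter-Glo, with a stated time of 72 h (a higher number here means a weaker inhibitor of growth, a lower number a stronger inhibitor of growth), compound 1 gives 43 nM, and compound 2 `C=CC(=O)Nc1cc(Nc2ncc(Cl)c(Nc3ccccc3S(=O)(=O)C(C)C)n2)c(OC)cc1N1CCN(C2CCCCC2)CC1` gives 77 nM. Among the measured compounds shown here, the only measured step, a 1.8-fold higher number from compound 1 to compound 2 (0.25 log units; within the scatter), puts cyclohexyl in place of methyl on an amine nitrogen in a ring and stays within the scatter. Compound 3 `C=CC(=O)Nc1cc(Nc2ncc(Cl)c(Nc3ccc(F)c(Cl)c3)n2)c(OC)cc1N1CCN(C)CC1` differs from compound 1 by 3-chloro-4-fluorophenyl in place of 2-(isopropylsulfonyl)phenyl on a nitrogen on an aromatic ring. For the measured compounds named here, no measured step touches this part of the core of compound 1, so nothing among the data tells the direction or the size of the change in this assay. The expectation for compound 3 therefore rests on compound 1 alone, with a wide range, and the step is estimated as a 2.8-fold higher number from compound 1 to compound 3 (0.45 log units; beyond the scatter). Compound 3 is expected to give about 120 nM in this assay, with a range from 25 nM to 600 nM.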

Compound 3, concentration for 50% growth inhibition: 100 nM
Compound 3: middle estimate off by 1.2-fold (0.08 log units), on the high side; low and high end bracket the measured number.
By their numbers in this assay, from the lowest: compounds 1, 2 and 3 (each within the scatter of the next, the first and the last beyond it).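

Among these compounds, the first change on this nitrogen on an aromatic ring, 3-chloro-4-fluorophenyl in place of 2-(isopropylsulfonyl)phenyl, gives a 2.3-fold higher number from compound 1 to compound 3 (0.37 log units; beyond the scatter) in this assay, a step beyond the scatter, whereas the earlier step on the amine nitrogen in a ring stayed within it. The result shows that this position affects the number, yet the change remains modest even though the entering group has no hydrogen-bond acceptors and the leaving group has two. Nothing available gives a reason for this step.

The compounds shown leave open whether the step follows from losing the isopropylsulfonyl group or from adding the chlorine and fluorine. A plain phenyl or a 2-(methylsulfonyl)phenyl in this place could separate those two parts of the change.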